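Taking One Fluoro Group from Compound 3

This account rests on a few compounds, and the source may have more. Where it says the series, first, only, none or still open, it means among the compounds named here.

Of the compounds shown here, three built on a shared core have been tested in a functional assay on KYSE-410 cells (Homo sapiens) for antiproliferative activity, read by MTT assay, with a stated time of 72 h; a lower number here means a stronger inhibitor, a higher number a weaker inhibitor. There, compound 1 (`O=C(Nc1cccc(F)c1)c1cc(=O)[nH]c2cc(Br)ccc12`) gives 7300 nM. Compound 2 (`CC(C)(C)c1ccc(NC(=O)c2cc(=O)[nH]c3cc(Br)ccc23)cc1`) is reported only as a limit, > 20000 nM. Compound 3 (`O=C(Nc1cc(F)c(F)c(F)c1)c1cc(=O)[nH]c2cc(Br)ccc12`) is also reported only as a limit, > 20000 nM. It therefore stands at the limit of > 20000 nM in this assay, at which 2 of the 3 values shown sit, and no exact number is known for it.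

Compound 4 (`O=C(Nc1cc(F)cc(F)c1)c1cc(=O)[nH]c2cc(Br)ccc12`) differs from compound 3 by a single change, (hydrogen in place of fluoro on an aromatic carbon). Hydrogen takes the place of fluoro on an aromatic carbon, ortho to two fluoro groups and para to a large group. Compound 1, at 7300 nM, shows that a fluoro-substituted ring on this core can give a measurable number, and this supports the expectation of a modest gain. The estimated step of an at least 1.6-fold lower number from compound 3 to compound 4 (0.22 log units; that floor lies within the scatter) in this assay points toward stronger inhibition, though it is expected to be small. For compound 4 the expected value is 12000 nM, with an estimated range of 5000 nM to 25000 nM.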

Compound 4, half-maximal inhibitory concentration: 11200 nM
Estimate against measurement, compound 4: 1.1-fold (0.03 log units) above; the range from low to high includes it.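

In this assay, hydrogen in place of fluoro on an aromatic carbon gives an at least 1.7-fold lower number from compound 3 to compound 4 (0.25 log units; that floor lies within the scatter), so this change yields a measured number where there was none before, although the step cannot be told apart from the scatter. Compound 3 is reported only as a limit, so the step has a floor and no exact size: the limit of > 20000 nM in this assay, at which 2 of the 4 values shown sit. The other step, a 1.5-fold higher number from compound 1 to compound 4 (0.19 log units; within the scatter), shows that fluoro in place of hydrogen on an aromatic carbon leaves compound 1 and compound 4 level within the scatter.

Going by these compounds, it remains open how far compound 3 really lies from compound 4, since its exact number is unknown. On these data alone, it is also open whether a methoxy group, an amine or a carboxylic acid on this aromatic carbon would move the number beyond the scatter.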